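Swapping a Nitrophenyl for a Difluorophenyl at the Limit

A few compounds are considered here, and "the series" means these few. Any claim that something is new, unique, unknown or untested is made for them only; others in the source may bear on it.

All three measured compounds share one core. Compound 1 `CC(C)[C@H](NC(=O)COc1cccc2ccccc12)C(=O)N[C@@H](CC(=O)O)C(=O)COc1ccc(-c2ccccc2)cc1` gives, in a functional assay on Jurkat cells (Homo sapiens) (a lower number here means a stronger inhibitor, a higher number a weaker inhibitor), 87900 nM. Compound 2 `CC(C)[C@H](NC(=O)COc1cccc2ccccc12)C(=O)N[C@@H](CC(=O)O)C(=O)COc1cc(C(F)(F)F)cc(C(F)(F)F)c1` reaches only the limit of the assay, > 100000 nM, which is not a number. Compound 3 `CC(C)[C@H](NC(=O)COc1cccc2ccccc12)C(=O)N[C@@H](CC(=O)O)C(=O)COc1ccccc1[N+](=O)[O-]` likewise sits at the limit, > 100000 nM. Going by the values given here, the only single-place step among the measured compounds is an at least 1.1-fold higher number from compound 1 to compound 3 (0.05 log units; that floor lies within the scatter), too small to count as a change. Compound 3 thus stands at the weak end of what this assay can report, since the limit of > 100000 nM in this assay, at which 2 of the 3 values shown sit, marks where most of the values stop.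

Compound 4 `CC(C)[C@H](NC(=O)COc1cccc2ccccc12)C(=O)N[C@@H](CC(=O)O)C(=O)COc1cc(F)cc(F)c1` is not yet measured. It differs from compound 3 in one place: 3,5-difluorophenyl in place of 2-nitrophenyl on an oxygen on a saturated carbon. Among the compounds with values here, no measured step bears directly on this exchange; the one known step stayed within the scatter, and compound 2 offers no second step. Within the data shown here, with every variation so far leaving the number at or near the limit, compound 4 is expected to change little, a number no higher from compound 3 to compound 4 (the limit leaves the size open), and its estimate is 100000 nM, within 40000 nM to 300000 nM.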

Compound 4, half-maximal inhibitory concentration: > 100000 nM
Compound 4: only a limit was reported; the forecaster's own chance of this, stated with the estimate: 60%; the middle value lies on the limit itself.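

In this assay compound 4 gives > 100000 nM, which is a limit of the assay and not a number. The only readable comparison is an at least 1.1-fold higher number from compound 1 to compound 4 (0.05 log units; that floor lies within the scatter), so exchanging 4-phenylphenyl for 3,5-difluorophenyl on this oxygen is not shown to change anything. The exchange of 2-nitrophenyl for 3,5-difluorophenyl cannot be read, and a third group at this position now ends at the same point: the limit of > 100000 nM in this assay, at which 3 of the 4 values shown sit.

On these data alone, compounds 2, 3 and 4 cannot be put in any order, and it remains open whether any group at this position can bring the number clearly below the limit. As far as these compounds go, how a plain phenyl, or a phenyl carrying an amine or a carboxylic acid, would read here also stays unknown.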